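This account rests on a few compounds, and the source may have more. Where it says the series, first, only, none or still open, it means among the compounds named here.

Working notes on the series. All three measured compounds share one core, shown first as compound 1 `CCCCN(CC)c1cc(C)nc2c1NC(=O)CN2c1ccc(C)cc1C`, which in an assay on HEK-293T cells for displacement of a labelled ligand from corticotropin-releasing factor receptor 1 (Homo sapiens), read by scintillation counting, with a stated time of 2 h (on this read-out lower numbers stand for stronger inhibition and higher numbers for weaker inhibition), gives 3.9 nM. Compound 2 `CCCCN(CC)c1cc(C)nc2c1NC(=O)CN2c1ccc(C(C)C)cc1Br` gives 2.4 nM, and compound 3 `CCCN(CCC)c1cc(C)nc2c1NC(=O)CN2c1ccc(C(C)C)cc1Br` gives 3.1 nM. Among these three numbers compound 3 stands second highest; its gap to compound 1 and its gap to compound 2 both lie within the scatter, so no order among the three can be read from them. Among the compounds with values here, the only single-point step measured so far on the amino substituent is a 1.3-fold higher number from compound 2 to compound 3 (0.11 log units; within the scatter), where one dialkylamino group is exchanged for another of like size and the number is essentially unchanged.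

Compound 4 `CCN(C)c1cc(C)nc2c1NC(=O)CN2c1ccc(C(C)C)cc1Br` is the next compound to be run. It differs from compound 3 by ethyl(methyl)amino in place of dipropylamino on an aromatic carbon. The step from compound 2 to compound 3 bears on it only loosely, since there the amino substituent kept its size, whereas here the much shorter ethyl(methyl)amino enters. Within the data shown here, no measured step covers a reduction of that kind, so a moderate rise in the number, beyond the scatter, is expected rather than none, namely a 3.9-fold higher number from compound 3 to compound 4 (0.59 log units; beyond the scatter). For compound 4 the estimate in this assay is 12 nM, with a range from 3 nM to 50 nM.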

Compound 4, inhibition constant: 16.4 nM
Compound 4: the middle estimate sits 1.4-fold (0.14 log units) below what was measured, and the stated range covers the measured number.
By their numbers in this assay, from the lowest: compounds 2, 3 and 1 (each within the scatter of the next); then compound 4.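

In this assay, the amino substituent on this aromatic carbon, opposite the ring nitrogen, now shows a change beyond the scatter: ethyl(methyl)amino in place of dipropylamino gives a 5.3-fold higher number from compound 3 to compound 4 (0.72 log units; beyond the scatter) as 4 heavy atoms enter where 7 leave, a modest step that contrasts with the earlier exchange between two larger groups, which stayed within the scatter. Starting from the other larger group, butyl(ethyl)amino, the same ethyl(methyl)amino gives a 6.8-fold higher number from compound 2 to compound 4 (0.83 log units; beyond the scatter) and is again modest, so both larger groups stand apart from ethyl(methyl)amino in this series, while compound 4 still gives 16.4 nM and binding is not lost at this position. Nothing available here bears on why the number rises with this change.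

The three amino groups shown cannot tell whether the number climbs gradually with chain length or shifts once below a certain size, and diethylamino or dibutylamino at the same carbon would bear on that. Going by these compounds, how a morpholine at this carbon would read, or whether the same shortening carries the same step alongside the aryl group of compound 1, also stays open.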